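This account rests on a few compounds, and the source may have more. Where it says the series, first, only, none or still open, it means among the compounds named here.

Within the data shown here, compound 1 `CCOC(=O)C1=Cc2ccccc2OC1(OCc1cn(-c2ccc(F)cc2)nn1)C(F)(F)F` is the only member of the series with a number in a functional assay on HeLa cells (Homo sapiens) for inhibition, read by MTT assay, with a stated time of 24 h; a higher number here means a weaker inhibitor, a lower number a stronger inhibitor: compound 1 gives 8400 nM. Compound 2 `CCOC(=O)C1=Cc2ccccc2OC1(OCc1cc(-c2ccc(F)cc2F)no1)C(F)(F)F` returns only a limit in this assay, > 150000 nM. Compound 3 `CCOC(=O)C1=Cc2ccccc2OC1(OCc1cc(-c2ccc(C)cc2)no1)C(F)(F)F` likewise returns only a limit in this assay, > 150000 nM. Among the measured compounds shown here, the one measured step, a step that the two limits leave unreadable from compound 2 to compound 3, cannot be read because both of its ends sit at the limit of > 150000 nM in this assay, at which 2 of the 3 values shown sit.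

Compound 4 `CCOC(=O)C1=Cc2ccccc2OC1(OCc1cn(CC(=O)NC2CCCCC2)nn1)C(F)(F)F` has not been measured in this assay. It differs from compound 1 by (cyclohexylcarbamoyl)methyl in place of 4-fluorophenyl on an aromatic nitrogen. For the measured compounds named here, no measured step touches the group on the aromatic nitrogen of the five-membered aromatic ring with 3 nitrogen; the single unreadable step concerns a different ring and gives no size. In this assay, then, no step beyond the scatter can be expected in either direction from the evidence shown, and the estimate for compound 4 rests on compound 1 alone. For compound 4 a value of 15000 nM is expected, with a range of 3000 nM to 80000 nM. The step this implies, a 1.8-fold higher number from compound 1 to compound 4 (0.25 log units; within the scatter), is expected to lie within the scatter, though the range is wide.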

Compound 4, half-maximal inhibitory concentration: 11400 nM
The estimate for compound 4 lay 1.3-fold (0.12 log units) above the measured number; the range from low to high includes it.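

On the aromatic nitrogen of the five-membered aromatic ring with 3 nitrogen, (cyclohexylcarbamoyl)methyl in place of 4-fluorophenyl gives a 1.4-fold higher number from compound 1 to compound 4 (0.13 log units; within the scatter) in this assay. Among these compounds, this is the first readable step, and it bears directly on this position. The exchange replaces a six-membered aromatic ring of carbon only with a non-aromatic one and adds a hydrogen-bond donor and a hydrogen-bond acceptor, so for this pair an aromatic ring on this nitrogen is not needed for a readable number.

On these data alone, whether the same holds for other groups on this nitrogen, such as an amine on a longer chain or a carboxylic acid, remains open. The steps around the other ring type cannot be read, as compound 2 and compound 3 each return only a limit of the assay: the limit of > 150000 nM in this assay, at which 2 of the 4 values shown sit.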